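This account rests on a few compounds, and the source may have more. Where it says the series, first, only, none or still open, it means among the compounds named here.

Measured so far in an assay for binding affinity to dual specificity mitogen-activated protein kinase kinase 4 (Homo sapiens), read by KINOMEscan, tested at 100 nM; on this read-out higher numbers stand for a weaker effect at the one concentration tested and lower numbers for a stronger effect:
Compound 1 `CCCS(=O)(=O)Nc1ccc(F)c(C(=O)c2n[nH]c3ncc(-c4cccc(Cl)c4)cc23)c1F` gives 40%
Compound 2 `CCCS(=O)(=O)Nc1ccc(F)c(C(=O)c2n[nH]c3ncc(-c4ccccc4O)cc23)c1F` gives 9%
Compound 3 `CCCS(=O)(=O)Nc1ccc(F)c(C(=O)c2n[nH]c3ncc(-c4ccc(C)c(C)c4)cc23)c1F` gives 20%

Compound 3 stands second highest of the three numbers in this assay. Its nearest neighbour is compound 2, with a step of a number 11 percentage points higher from compound 2 to compound 3 (beyond the scatter); its furthest is compound 1, with a step of a number 20 percentage points lower from compound 1 to compound 3 (beyond the scatter).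

The next compound, compound 4 `CCCS(=O)(=O)Nc1ccc(F)c(C(=O)c2n[nH]c3ncc(-c4ccc([N+](=O)[O-])cc4)cc23)c1F`, has not yet been measured. It differs from compound 3 in one place: 4-nitrophenyl in place of 3,4-dimethylphenyl on an aromatic carbon.

Every measured step changes this same aryl group, so all three bear on it: a number 31 percentage points lower from compound 1 to compound 2 (beyond the scatter), a number 20 percentage points lower from compound 1 to compound 3 (beyond the scatter) and a number 11 percentage points higher from compound 2 to compound 3 (beyond the scatter). They range from modest to large, and each lies beyond the scatter. Among the compounds with values here, no measured compound carries a nitro group, so the direction of the change cannot be read from the data; only its likely size can. A modest step in this assay, in either direction, is therefore expected.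

For compound 4 the expected value is 30%, estimated to lie between 10% and 65%, which means an expected step of a number 10 percentage points higher from compound 3 to compound 4 (within the scatter).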

Compound 4, a percentage reported as activity, at one concentration (the size of the read-out at that concentration, not a potency): 4.2%
Compound 4: middle estimate off by 25.8 percentage points, on the high side; the measured number lies below the stated range.
By their numbers in this assay, from the lowest: compounds 4 and 2 (each within the scatter of the next); then compound 3; then compound 1.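

The change to 4-nitrophenyl moves the read-out in this assay towards a stronger effect, with a number 15.8 percentage points lower from compound 3 to compound 4 (beyond the scatter) and a number 35.8 percentage points lower from compound 1 to compound 4 (beyond the scatter). Compound 2 no longer stands alone at the low end of the series: with a number 4.8 percentage points lower from compound 2 to compound 4 (within the scatter), two different aryl groups, 2-hydroxyphenyl and 4-nitrophenyl, sit level at this position, so a low number here does not depend on the hydroxyl group. Nothing available explains why these two groups read alike or why either differs from 3,4-dimethylphenyl.

Going by these compounds, whether an amine or a carboxylic acid in place of the nitro group would stay in this low range remains open. Also open, on these data alone, is whether the same order of aryl groups would hold on any other kinase.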